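Dropping the bromo group from the outer phenyl ring

The source may hold more compounds than are shown below. What is called first, only, known or untested is meant among the compounds shown, and "the series" means these compounds.

Compound 1 `O=C(c1ccc2c(c1)OCCO2)C1CCN(Cc2coc(-c3ccc(Cl)cc3)n2)CC1` is the starting point of this small series. In an ADME assay on HEK293 cells (Homo sapiens) for cytotoxicity, read by MTT assay, with a stated time of 36 h (a lower number here means a stronger inhibitor, a higher number a weaker inhibitor), compound 1 gives > 150 ug/mL, which is a limit of the assay rather than a measured number. Compound 2 `O=C(c1ccc2c(c1)OCCO2)C1CCN(Cc2coc(-c3ccc(Br)cc3)n2)CC1` carries bromo in place of chloro on an aromatic carbon. In this assay compound 2 gives > 150 ug/mL, again a limit and not a number. The step that the two limits leave unreadable from compound 1 to compound 2 is therefore unreadable because of the limit of > 150 ug/mL in this assay, at which 2 of the 2 values shown sit. For the measured compounds named here, compound 2 thus stands at the limit, and the one other value shown is also a limit. Compound 3 `O=C(c1ccc2c(c1)OCCO2)C1CCN(Cc2coc(-c3ccccc3)n2)CC1` differs from compound 2 by hydrogen in place of bromo on an aromatic carbon. Going by the values given here, no measured step bears readably on this change, so no step size in this assay can be drawn from the numbers; the two limits make a further limit the likeliest outcome. Compound 3 is expected to give about 200 ug/mL, between 100 ug/mL and 400 ug/mL. The step that the limit leaves unreadable from compound 2 to compound 3 is expected to stay within the usual scatter.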

Compound 3, half-maximal inhibitory concentration: > 150 ug/mL
Compound 3: a limit, no number (the forecaster's own chance of this, stated with the estimate: 75%); the middle value lies beyond the limit too.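

For the compounds shown here, compound 3 also sits at a limit, so no step among compound 1, compound 2 and compound 3 can be read: the limit of > 150 ug/mL in this assay, at which 3 of the 3 values shown sit. Going by these compounds, whether these three compounds differ at all in this assay, and at what concentration any of them would reach half-maximal inhibition, stays open.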